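The source may hold more compounds than are shown below. What is called first, only, known or untested is meant among the compounds shown, and "the series" means these compounds.

Measured compounds:
Compound 1 `Cc1ccc(-c2ccc3c(c2)C(=O)C(=O)N3)cc1` in a functional assay on K562 cells (Homo sapiens) for antiproliferative activity, read by MTT assay, with a stated time of 48 h (on this read-out higher numbers stand for weaker inhibition and lower numbers for stronger inhibition), gives only a limit, > 10000 nM.
Compound 2 `COc1ccc(-c2ccc3c(c2)C(=O)C(=O)N3Cc2ccc(Cl)cc2)cc1` in this assay gives 350 nM.

Among the two values shown, compound 2 carries the only actual number; the other entry belongs to compound 1 and is the limit of > 10000 nM in this assay, at which 1 of the 2 values shown sits, so the pair does not give a measured step that can be read for size. Compound 2 is therefore the only anchor for what follows.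

Compound 3 `COc1ccc(-c2ccc3c(c2)C(=O)C(=O)N3Cc2cc(C)cc(C)c2)cc1` keeps the whole of compound 2 except for one exchange: 3,5-dimethylphenyl in place of 4-chlorophenyl on a saturated chain carbon bound to an amide-type nitrogen in a ring. The shared core, its two carbonyl groups and the methoxyphenyl arm are untouched; only the aromatic ring hanging from the saturated chain carbon on the ring nitrogen is swapped.

Within the data shown here, with no measured step of this kind to lean on, the change is expected to move the value by little, if at all, beyond the usual scatter, in either direction. The step from compound 2 to compound 3 is estimated at a 1.3-fold higher number from compound 2 to compound 3 (0.11 log units; within the scatter). On that basis compound 3 is expected to give about 450 nM in this assay, within a range of 150 nM to 1400 nM.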

Compound 3, half-maximal inhibitory concentration: 140 nM
Beside the measured number, compound 3's estimate is 3.2-fold (0.51 log units) above it; measured number outside the range, below it.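

In this assay, among these compounds, exchanging 4-chlorophenyl for 3,5-dimethylphenyl on a saturated chain carbon bound to an amide-type nitrogen in a ring gives a 2.5-fold lower number from compound 2 to compound 3 (0.40 log units; beyond the scatter), the first step at this position that can be read for size. It shows that this position responds to a change of the aromatic ring alone, with the shared core, both carbonyl groups and the methoxyphenyl arm left as they were, and that the chlorine of compound 2 is not required for a value in this range, since compound 3 carries none and gives the lower number. No measurement shown here explains why the number falls with this exchange.

Because the chlorine leaves and the two methyl groups enter in a single step, the compounds shown cannot tell how much of the change belongs to the loss of one or the gain of the other. Also open, on these data alone, is how the value would respond to an amine or a carboxylic acid on this aromatic ring, or to a longer chain joining the ring to the nitrogen.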